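The compounds below may be only part of what the source reports. "The series", "measured", "known", "first", "only" and "open" are said of these compounds alone.

Readings in a functional assay on the whole organism (strain C57B/6) with Mus musculus as the target, in the maximal electroshock model; on this read-out lower numbers stand for an effect already at smaller amounts and higher numbers for an effect only at larger amounts of compound:

compound 1 `CCCCCCOc1ccc(-n2cnnc2C)cc1`: 22.8 mg/kg
compound 2 `CCCCCCCCCc1nncn1-c1ccc(OCCCCCC)cc1`: limit only
compound 3 `CCCCCCOc1ccc(-n2cnnc2-c2ccc(F)cc2)cc1`: 22 mg/kg

In this assay compound 2 reports only a limit, > 40 mg/kg (the limit of > 40 mg/kg in this assay, at which 1 of the 3 values shown sits). Compound 1 and compound 3 sit within the scatter of each other, a 1.0-fold lower number from compound 1 to compound 3 (0.02 log units; within the scatter). Compound 4 `CCCCCCOc1ccc(-n2cnnc2-c2ccc(C)cc2)cc1` has not been measured. It differs from compound 2 in one place: 4-methylphenyl in place of nonyl on an aromatic carbon. The step that bears most directly on it is an at least 1.8-fold lower number from compound 2 to compound 3 (0.25 log units; that floor lies within the scatter), where an aromatic ring likewise replaced the nonyl chain on the same aromatic carbon of the core; that step can only be given as a floor, since compound 2 has no fixed number. The exchange of methyl for 4-fluorophenyl on that carbon, a 1.0-fold lower number from compound 1 to compound 3 (0.02 log units; within the scatter), left the number unchanged, so the methyl on the entering ring is not expected to move the value away from compound 3. For compound 4 the expected step is an at least 1.8-fold lower number from compound 2 to compound 4 (0.25 log units; that floor lies within the scatter). Compound 4 is estimated at 22 mg/kg, with a range from 10 mg/kg to 45 mg/kg.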

Compound 4, dose for half-maximal effect: 11.4 mg/kg
For compound 4 the middle estimate is 1.9-fold (0.29 log units) above the measured one; low and high end bracket the measured number.
By their numbers in this assay, from the lowest: compounds 4, 3 and 1 (each within the scatter of the next). At a limit, above all of these: compound 2.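

Among these compounds, at the aromatic carbon between two ring nitrogen atoms, 4-methylphenyl in place of nonyl is the first exchange in this assay to clear the scatter, with an at least 3.5-fold lower number from compound 2 to compound 4 (0.54 log units; beyond the scatter). That step remains a floor, as compound 2 stands only as a limit: the limit of > 40 mg/kg in this assay, at which 1 of the 4 values shown sits.

The other two steps do not resolve the groups at this carbon, with a 1.9-fold lower number from compound 3 to compound 4 (0.29 log units; within the scatter) for methyl in place of fluoro on the entering ring and a 2.0-fold lower number from compound 1 to compound 4 (0.30 log units; within the scatter) for 4-methylphenyl in place of methyl, so the separation holds only against nonyl.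

Open, going by these compounds, is how a chain of intermediate length, such as butyl, would read at this carbon, between methyl and nonyl. Also open, on these data alone, is whether an amine or a carboxylic acid on the entering phenyl ring would fit this series.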